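Aryl cyanoguanidines in rat aorta: from compound 2 to compound 3

The source may report more compounds than this note shows. Statements on the series, on what has been measured and on what is new or still open speak of the compounds shown alone.

compound 1 `CC1(C)Oc2ccc(C#N)cc2[C@@H](/N=C(\NC#N)Oc2ccccc2)[C@@H]1O`; in a functional assay (aorta) with Rattus norvegicus as the target (a lower number here means a stronger inhibitor, a higher number a weaker inhibitor), compound 1 gives > 100000 nM
compound 2 `COC(=O)c1cccc(N/C(=N/[C@@H]2c3cc(C#N)ccc3OC(C)(C)[C@H]2O)NC#N)c1`; in this assay compound 2 gives 4100 nM

The value of compound 1 is a limit of the assay, not a number; compound 1 sits at the limit of > 100000 nM in this assay, at which 1 of the 2 values shown sits. Compound 2 holds the only number shown in this assay. Compound 3 `CSc1ccc(N/C(=N/[C@@H]2c3cc(C#N)ccc3OC(C)(C)[C@H]2O)NC#N)cc1` is not yet measured; it differs from compound 2 by 4-(methylsulfanyl)phenyl in place of 3-(methoxycarbonyl)phenyl on an amine nitrogen. Among the compounds with values here, no measured pair carries this change, so no step size is known for it. The step is expected to lie within the usual scatter, with no clear direction: a 1.2-fold lower number from compound 2 to compound 3 (0.07 log units; within the scatter). Compound 3 is expected to give 3500 nM, between 700 nM and 18000 nM.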

Compound 3, half-maximal inhibitory concentration: 6300 nM
Estimate against measurement, compound 3: 1.8-fold (0.26 log units) below, and the stated range covers the measured number.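

In this assay, the amine nitrogen tolerates 4-(methylsulfanyl)phenyl in place of 3-(methoxycarbonyl)phenyl, with no clear change: a 1.5-fold higher number from compound 2 to compound 3 (0.19 log units; within the scatter). On the carbon with a double bond to nitrogen, (4-(methylsulfanyl)phenyl)amino in place of phenoxy gives the first readable large step, an at least 15-fold lower number from compound 1 to compound 3 (1.20 log units; beyond the scatter). The value of compound 1 is a limit of the assay, not a number: the limit of > 100000 nM in this assay, at which 1 of the 3 values shown sits.

Still open, going by these compounds, is whether an unsubstituted phenyl on the amine nitrogen would give a number like those of compound 2 and compound 3. Also open, on these data alone, is how a carboxylic acid or a dimethylamino group on that phenyl would read in this assay.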